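Shortening the ester chain between the two esters

This account rests on a few compounds, and the source may have more. Where it says the series, first, only, none or still open, it means among the compounds named here.

Within the data shown here, compound 1 `CCCC(=O)OCCCCOC(=O)c1ccc(C(=O)Nc2ccc3c(c2)C(C)(C)CCC3(C)C)cc1` gives the lower of the two numbers measured so far: in a functional assay on NB-4 cells (Homo sapiens) for inhibition, read by MTT assay, with a stated time of 48 h (on this read-out lower numbers stand for stronger inhibition and higher numbers for weaker inhibition), compound 1 gives 23200 nM, whereas compound 2 `Cc1cc2c(cc1C(=O)c1ccc(C(=O)OCCCOC(=O)c3ccc(C(=O)Nc4ccc5c(c4)C(C)(C)CCC5(C)C)cc3)cc1)C(C)(C)CCC2(C)C` gives 112000 nM in this assay, a gap beyond the scatter. Compound 3 `CCCC(=O)OCCOC(=O)c1ccc(C(=O)Nc2ccc3c(c2)C(C)(C)CCC3(C)C)cc1` differs from compound 1 by (propylcarbonyl)oxy in place of 2-((propylcarbonyl)oxy)ethyl on a saturated chain carbon, two bonds along the chain from an oxygen next to a carbonyl group. Among the measured compounds shown here, no step between measured compounds covers this kind of change, so the estimated step from compound 1 to compound 3 in this assay is a 1.2-fold lower number from compound 1 to compound 3 (0.06 log units; within the scatter), expected to stay within the scatter. Compound 3 is therefore expected to give about 20000 nM in this assay, with a range from 7000 nM to 60000 nM.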

Compound 3, half-maximal inhibitory concentration: 11000 nM
The estimate for compound 3 lay 1.8-fold (0.26 log units) above the measured number; measured number inside the range.
By their numbers in this assay, from the lowest: compound 3; then compound 1; then compound 2.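

In this assay, the change from 2-((propylcarbonyl)oxy)ethyl to (propylcarbonyl)oxy on this saturated chain carbon gives a 2.1-fold lower number from compound 1 to compound 3 (0.32 log units; beyond the scatter), so this position does respond to the change, though modestly. This is a single step, and it shows no trend with chain length. Nothing available explains the step. The compounds shown leave open where a 3-((propylcarbonyl)oxy)propyl chain would stand, and whether an amine or a carboxylic acid in place of the (propylcarbonyl)oxy group would keep this number.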